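The source may hold more compounds than are shown below. What is called first, only, known or untested is meant among the compounds shown, and "the series" means these compounds.

Measured so far:
- compound 1 `CCn1cc(-c2nc3ccccc3[nH]2)c(=O)c2cc(F)c(N3CCNCC3)nc21`: 4800 nM
- compound 2 `CCn1cc(-c2nc3ccccc3o2)c(=O)c2cc(F)c(Cl)cc21`: 78400 nM

In a functional assay on A2780 cells (Homo sapiens) for cytotoxicity, read by MTT assay, with a stated time of 48 h (on this read-out lower numbers stand for stronger inhibition and higher numbers for weaker inhibition), compound 2 gives 78400 nM, the higher of the two numbers and clearly beyond the scatter of compound 1, so it is the weaker of the pair. The next structure, compound 3 `CCn1cc(-c2nc3ccccc3o2)c(=O)c2cc(F)c(N3CCN(C)CC3)cc21`, has 4-methylpiperazin-1-yl in place of chloro on an aromatic carbon, ortho to a fluoro group: 4-methylpiperazin-1-yl in place of chloro on an aromatic carbon.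

Going by the values given here, no measured pair isolates this change, so the only guide is indirect. Compound 1 also carries a six-membered non-aromatic ring with 2 hetero atoms and gives 4800 nM, although it differs from compound 2 in other places too. A clear move towards stronger inhibition in this assay is therefore expected, beyond the scatter. The expected change is a 9.8-fold lower number from compound 2 to compound 3 (0.99 log units; beyond the scatter). For compound 3 the estimated value is 8000 nM, with an expected range of 2000 nM to 30000 nM.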

Compound 3, half-maximal inhibitory concentration: 700 nM
The estimate for compound 3 lay 11-fold (1.06 log units) above the measured number, outside the stated range (below it).
By their numbers in this assay, from the lowest: compound 3; then compound 1; then compound 2.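

In this assay the exchange of chloro for 4-methylpiperazin-1-yl on this aromatic carbon, ortho to a fluoro group, gives a 110-fold lower number from compound 2 to compound 3 (2.05 log units; beyond the scatter) and so marks a large move towards stronger inhibition. This is the first pair shown that differs in one place only, so the gain can be tied directly to this change rather than to several differences at once. It also shows that the group on this carbon can strongly shift cytotoxicity on the shared core, though nothing shown accounts for the size of the step.

With only chloro and 4-methylpiperazin-1-yl shown at this position on this core, it remains open whether the ring as a whole is needed. An open-chain amine such as dimethylamino, or a morpholin-4-yl ring with an oxygen atom in place of the methylated nitrogen, could separate these possibilities.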